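Trifluoromethoxy for methoxy on a shared triazolothiadiazine core

The source may hold more compounds than are shown below. What is called first, only, known or untested is meant among the compounds shown, and "the series" means these compounds.

Measured so far:
Compound 1, `COc1ccc2cc(C(C)c3nnc4n3N=C(c3ccc(C)cc3)CS4)ccc2c1`: in a functional assay on MCF7 cells (Homo sapiens) for inhibition, read by sulforhodamine B assay, with a stated time of 72 h (a lower number here means a stronger inhibitor, a higher number a weaker inhibitor), compound 1 gives 11000 nM.
Compound 2, `COc1ccc(C2=Nn3c(nnc3C(C)c3ccc4cc(OC)ccc4c3)SC2)cc1`: in this assay compound 2 gives 6600 nM.
Compound 3, `CC(C)Cc1ccc(C(C)c2nnc3n2N=C(c2ccc(F)cc2)CS3)cc1`: in this assay compound 3 gives 8900 nM.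

Compound 2 holds the lowest of the three numbers, yet its distances to compound 3 and to compound 1 both lie within the scatter, so no order among them can be claimed. Compound 4, `COc1ccc2cc(C(C)c3nnc4n3N=C(c3ccc(OC(F)(F)F)cc3)CS4)ccc2c1`, is not yet measured. It differs from compound 2 by trifluoromethyl in place of methyl on an oxygen on an aromatic ring, that is, methoxy to trifluoromethoxy. Within the data shown here, only one measured step bears on this: a 1.7-fold lower number from compound 1 to compound 2 (0.22 log units; within the scatter), a methyl exchanged for a methoxy on an aromatic carbon, not the same change. Among the measured compounds shown here, with no precedent for the new group, no step beyond the scatter is expected. Compound 4 is therefore estimated at 7000 nM, ranging from 3000 nM to 16000 nM, which means an expected step of a 1.1-fold higher number from compound 2 to compound 4 (0.03 log units; within the scatter).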

Compound 4, half-maximal inhibitory concentration: 8800 nM
Compound 4: middle estimate off by 1.3-fold (0.10 log units), on the low side; the range from low to high includes it.
By their numbers in this assay, from the lowest: compounds 2, 4, 3 and 1 (each within the scatter of the next).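

Changing 4-methoxyphenyl to 4-(trifluoromethoxy)phenyl gives a 1.3-fold higher number from compound 2 to compound 4 (0.12 log units; within the scatter) in this assay at this place, and trifluoromethoxy in place of methyl on the aromatic carbon gives a 1.3-fold lower number from compound 1 to compound 4 (0.10 log units; within the scatter) in the same assay. The methyl, methoxy and trifluoromethoxy compounds therefore all stay within the scatter of one another, so this place has so far tolerated all three groups without a readable change. Nothing measured here offers a reason for this.

Going by these compounds, whether an amine, a carboxylic acid or a longer chain at this place would give a step beyond the scatter remains open.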